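Swapping the Chlorophenyl Arm of a Weak Chalcone

This account rests on a few compounds, and the source may have more. Where it says the series, first, only, none or still open, it means among the compounds named here.

Going by the values given here, compound 1 `O=C(COc1ccc(C(=O)/C=C/c2cccc(Cl)c2)cc1)N[C@H]1CCOC1=O` is the only member of this small set that returns an actual number in a functional assay on MCF7 cells (Homo sapiens) for antiproliferative activity, read by MTT assay, with a stated time of 72 h (a higher number here means a weaker inhibitor, a lower number a stronger inhibitor), where compound 1 gives 20900 nM. Compound 2 `Cc1ccc(C(C)C)c(OCCSC(=S)N[C@H]2CCOC2=O)c1` reaches only a limit of the assay in this assay, giving > 64000 nM. Compound 3 `O=C1OCC[C@@H]1NC(=S)SCCOc1ccccc1[N+](=O)[O-]` likewise sits at a limit in this assay, giving > 64000 nM. Among the compounds with values here, the picture around compound 1 is therefore thin: the limit of > 64000 nM in this assay, at which 2 of the 3 values shown sit, and no pair of measured compounds differs in just one place, so no measured step shows how a single change shifts activity here.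

Compound 4 `CC(C)(C)c1ccc(/C=C/C(=O)c2ccc(OCC(=O)N[C@H]3CCOC3=O)cc2)cc1` keeps the whole of compound 1 except at one spot: 4-(tert-butyl)phenyl in place of 3-chlorophenyl on a double-bonded chain carbon bound to a double-bonded chain carbon. Within the data shown here, nothing among the measured compounds shows what such an exchange of one aromatic group for another does in this assay. With no guide beyond the starting value of compound 1, the step expected from this change is small, a 1.0-fold lower number from compound 1 to compound 4 (0.02 log units; within the scatter), and not clearly beyond the usual scatter in either direction. Compound 4 is therefore estimated at 20000 nM, with a plausible range from 6000 nM to 64000 nM, and the coming measurement will show whether that expectation holds.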

Compound 4, half-maximal inhibitory concentration: 16400 nM
For compound 4 the middle estimate is 1.2-fold (0.09 log units) above the measured one; low and high end bracket the measured number.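

Going by these compounds alone, the exchange of 3-chlorophenyl for 4-(tert-butyl)phenyl on a double-bonded chain carbon bound to a double-bonded chain carbon gives the first measured single-place step in this assay, and that step is a 1.3-fold lower number from compound 1 to compound 4 (0.11 log units; within the scatter). This position therefore accepts two quite different aromatic arms, one carrying chlorine and one made of carbon alone, and the two resulting numbers cannot be told apart, so this one exchange leaves activity essentially where it was. Compound 4 also returns an actual number rather than a limit, so the shared core of compound 1 and compound 4 now has two measured values, while the other two values in the set remain limits: the limit of > 64000 nM in this assay, at which 2 of the 4 values shown sit.

Within the data shown here, the step covers only one pair of arms, so it cannot show whether this position is generally indifferent or whether these two groups merely happen to give similar numbers. As far as these compounds go, whether a 4-aminophenyl or a 4-carboxyphenyl arm in the same place would move the number beyond the usual scatter remains open, and so does the effect of a longer chain in place of the aromatic arm.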